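Cytotoxicity notes on the shared-core anilide series

This account rests on a few compounds, and the source may have more. Where it says the series, first, only, none or still open, it means among the compounds named here.

Measured compounds in an ADME assay on MT4 cells (Homo sapiens) for cytotoxicity, read by MTT assay, with a stated time of 5 days; on this read-out higher numbers stand for lower toxicity in this test and lower numbers for higher toxicity in this test:
compound 1, `O=C(CSc1snnc1-c1ccc(Br)cc1Br)Nc1ccccn1`, gives 42400 nM;
compound 2, `O=C(CSc1snnc1-c1ccc(Br)cc1Br)Nc1ccccc1`, gives 24800 nM;
compound 3, `O=C(CSc1snnc1-c1ccc(Br)cc1Br)Nc1ccc(Cl)cc1`, gives 23300 nM.

Compound 3 sits at the low end of the three numbers, yet the gaps to the others are small: a 1.8-fold lower number from compound 1 to compound 3 (0.26 log units; within the scatter) and a 1.1-fold lower number from compound 2 to compound 3 (0.03 log units; within the scatter). Compound 4, `Cc1ccc(NC(=O)CSc2snnc2-c2ccc(Br)cc2Br)cc1`, has not been measured. It differs from compound 3 by methyl in place of chloro on an aromatic carbon. The step bearing on it is the one at the same position, a 1.1-fold lower number from compound 2 to compound 3 (0.03 log units; within the scatter), which barely moved the number. The estimate for compound 4 in this assay is therefore a step of a 1.1-fold higher number from compound 3 to compound 4 (0.03 log units; within the scatter), nothing beyond the scatter. Compound 4 is expected at 25000 nM, within 12000 nM to 50000 nM.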

Compound 4, half-maximal cytotoxic concentration: 24000 nM
Compound 4: the middle estimate sits 1.0-fold (0.02 log units) above what was measured, and the stated range covers the measured number.
By their numbers in this assay, from the lowest: compounds 3, 4, 2 and 1 (each within the scatter of the next).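

In this assay, methyl on this aromatic carbon adds a third group to hydrogen and chloro with no separation among them: a 1.0-fold higher number from compound 3 to compound 4 (0.01 log units; within the scatter) and a 1.0-fold lower number from compound 2 to compound 4 (0.01 log units; within the scatter). The 4-methylphenyl group also stays within the scatter of pyridin-2-yl on the amide-type nitrogen, with a 1.8-fold lower number from compound 1 to compound 4 (0.25 log units; within the scatter). No supporting data explain this flat picture.

On these data alone, whether an amine, a carboxylic acid or a longer chain at this place would move the number remains open. So does the effect of any change to the shared core.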